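A few compounds are considered here, and "the series" means these few. Any claim that something is new, unique, unknown or untested is made for them only; others in the source may bear on it.

Measured so far in an in vitro assay on 293-EBNA cells for binding affinity to corticotropin-releasing factor receptor 1 (Homo sapiens); on this read-out higher numbers stand for weaker inhibition and lower numbers for stronger inhibition:

Compound 1, `CCN(CC)c1nc(C)nc2c1ncn2-c1ccc(C(C)C)cc1Br`, gives 12.4 nM.
Compound 2, `CCCCN(CCCC)c1nc(C)nc2c1ncn2-c1ccc(C(C)C)cc1Br`, gives 6.1 nM.
Compound 3, `CCCC(CCC)Nc1nc(C)nc2c1ncn2-c1ccc(C(C)C)cc1Br`, gives 3.6 nM.

Compound 3 holds the lowest number of the three; against compound 2 the gap is a 1.7-fold lower number from compound 2 to compound 3 (0.23 log units; within the scatter), so the two cannot be ordered, while against compound 1 it is a 3.4-fold lower number from compound 1 to compound 3 (0.54 log units; beyond the scatter).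

Compound 4 is `CCC(COC)Oc1nc(C)nc2c1ncn2-c1ccc(C(C)C)cc1Br`. The change from compound 3 is 1-(methoxymethyl)propoxy in place of (1-propylbutyl)amino on an aromatic carbon. All three measured steps concern only the group on this aromatic carbon, yet each keeps an amino group: a 2.0-fold lower number from compound 1 to compound 2 (0.31 log units; beyond the scatter) and a 3.4-fold lower number from compound 1 to compound 3 (0.54 log units; beyond the scatter) lie beyond the scatter, a 1.7-fold lower number from compound 2 to compound 3 (0.23 log units; within the scatter) within it. Within the data shown here, none replaces the nitrogen-linked group with an oxygen-linked one, so there is no direct precedent for the step to compound 4. The three measured compounds span a modest range, and the estimate for compound 4 is therefore placed near that range with wide bounds: compound 4 is expected at 9 nM, between 2.5 nM and 35 nM, which would mean an expected step of a 2.5-fold higher number from compound 3 to compound 4 (0.40 log units; beyond the scatter).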

Compound 4, inhibition constant: 9.7 nM
For compound 4 the middle estimate is 1.1-fold (0.03 log units) below the measured one; low and high end bracket the measured number.
By their numbers in this assay, from the lowest: compounds 3, 2, 4 and 1 (each within the scatter of the next, the first and the last beyond it).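

In this assay, 1-(methoxymethyl)propoxy on this aromatic carbon next to the ring nitrogen shows that the position accepts an oxygen-linked group, with a cost against (1-propylbutyl)amino: a 2.7-fold higher number from compound 3 to compound 4 (0.43 log units; beyond the scatter). Against the two dialkylamino groups no order can be drawn, with a 1.6-fold higher number from compound 2 to compound 4 (0.20 log units; within the scatter) and a 1.3-fold lower number from compound 1 to compound 4 (0.11 log units; within the scatter), so the oxygen-linked group sits among the nitrogen-linked ones rather than apart from them. Nothing available gives a reason for the step away from compound 3.

The step to compound 4 changes the linking atom and the chain together, so its size cannot be assigned to either one. A 1-propylbutoxy group or a [1-(methoxymethyl)propyl]amino group on the same carbon would separate the two, and a sulfur-linked chain would test the linking atom further.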